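Triazolyl in place of pyrimidinyl on the spiro-piperidine amide

The source may report more compounds than this note shows. Statements on the series, on what has been measured and on what is new or still open speak of the compounds shown alone.

Compound 1 `Cc1ccc(-c2ncccn2)c(C(=O)N2CCC3(CC3)C[C@H]2CNc2ccc(Cl)cn2)c1` in a functional assay on HEK293 cells for antagonist activity at Orexin receptor type 2 (Homo sapiens), read by FLIPR and calcium flux (on this read-out higher numbers stand for higher potency (the scale is a negative logarithm) and lower numbers for lower potency), gives only a limit, < 5. Compound 2 `Cc1nc(C(=O)N2CCC3(CC3)C[C@H]2CNc2ccc(Cl)cn2)c(-c2ccccc2)s1` likewise gives only a limit, < 5. Compounds 1 and 2 thus sit at the limit of < 5 in this assay, at which 2 of the 3 values shown sit. Compound 3 `Cc1ccc(OCc2ccccc2)c(C(=O)N2CC3(CC3)C[C@H]2CNc2ccc(C(F)(F)F)cn2)n1`, built on a different core, gives 8.6 in this assay. Among the compounds with values here, no pair of measured compounds differs in one place, so no measured step guides the change. Compound 4 `Cc1ccc(-n2nccn2)c(C(=O)N2CCC3(CC3)C[C@H]2CNc2ccc(Cl)cn2)c1` differs from compound 1 by 2H-1,2,3-triazol-2-yl in place of pyrimidin-2-yl on an aromatic carbon. Within the data shown here, with compound 1 at a limit and no related step to lean on, a modest rise in potency in this assay is expected for the change, while a result at the limit again remains possible. Compound 4 is estimated at 5.5, within 4.5 to 6.5. The expected step is a number at least 0.50 log units higher from compound 1 to compound 4 (beyond the scatter).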

Compound 4, negative logarithm of the antagonist equilibrium constant: < 5
Compound 4: no number, only a limit; the forecaster's own chance of this, stated with the estimate: 40%; middle value at least 0.50 log units away from the limit.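

Compound 1 and compound 4 both give only a limit in this assay, so no step between them can be read: the limit of < 5 in this assay, at which 3 of the 4 values shown sit.

The compounds shown leave open whether 2H-1,2,3-triazol-2-yl in place of pyrimidin-2-yl changes potency on the shared core at all.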